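Cytotoxicity notes: from compound 3 to compound 4

The source may hold more compounds than are shown below. What is called first, only, known or untested is meant among the compounds shown, and "the series" means these compounds.

Three measured members of the series share one core and differ only in the group on an aromatic carbon. Compound 1 is `CC(C)N(Cc1cccc(OCCCCCC(=O)O)c1)C(=O)c1ccc(-c2cccc(N(C)C)c2)cc1`. In an ADME assay on HepG2 cells (Homo sapiens) for cytotoxicity, read by CellTiter-Glo and resazurin assay, with a stated time of 72 h (a lower number here means that less compound is needed, a higher number that more compound is needed for the effect), compound 1 reports only the limit > 26000 nM. Compound 2 is `CC(=O)c1cccc(-c2ccc(C(=O)N(Cc3cccc(OCCCCCC(=O)O)c3)C(C)C)cc2)c1`. In this assay compound 2 likewise reports only the limit > 26000 nM. Compound 3 is `Cc1nnc(-c2cccc(-c3ccc(C(=O)N(Cc4cccc(OCCCCCC(=O)O)c4)C(C)C)cc3)c2)o1`. In this assay compound 3 also reports only the limit > 26000 nM. Compound 3 thus stands at the limit of > 26000 nM in this assay, at which 3 of the 3 values shown sit, and the numbers shown do not set it apart from the others. For the measured compounds named here, none of the measured steps can be sized: a step that the two limits leave unreadable from compound 1 to compound 2, a step that the two limits leave unreadable from compound 1 to compound 3 and a step that the two limits leave unreadable from compound 2 to compound 3 are all left unreadable by the two limits.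

Compound 4 is `COc1cc(F)cc(-c2ccc(C(=O)N(Cc3cccc(OCCCCCC(=O)O)c3)C(C)C)cc2)c1`. It differs from compound 3 by 3-fluoro-5-methoxyphenyl in place of 3-(5-methyl-1,3,4-oxadiazol-2-yl)phenyl on an aromatic carbon. The steps that start or end at compound 3 bear on this change most directly, and both are unreadable in size, so no direction can be drawn from them. The expected step for compound 4 is a step that the limit leaves unreadable from compound 3 to compound 4, meaning nothing beyond the scatter is anticipated. Compound 4 is estimated at 40000 nM in this assay, with a range from 18000 nM to 120000 nM, and a further limit rather than a number is the most likely report.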

Compound 4, half-maximal effective concentration: > 26000 nM
Compound 4 was reported as a limit; the forecaster's own chance of this, stated with the estimate: 85%; the middle value lies beyond the limit too.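

The steps from compound 1, compound 2 and compound 3 to compound 4 cannot be read, and all four compounds remain at one assay limit: the limit of > 26000 nM in this assay, at which 4 of the 4 values shown sit.

The compounds shown leave open whether changing the group on the aromatic carbon alters cytotoxicity at all, and at what concentration any of these four compounds would produce the effect.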